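The source may hold more compounds than are shown below. What is called first, only, known or untested is meant among the compounds shown, and "the series" means these compounds.

Compound 1 `CCCn1c(=O)[nH]c2nc(-c3ccc(S(=O)(=O)N4CCN(c5ccccc5Br)CC4)cc3)[nH]c2c1=O` — > 1000 nM, a limit of the assay.
Compound 2 `CCCn1c(=O)c2[nH]c(-c3ccc(S(=O)(=O)N4CCN(c5ccc(Cl)cc5)CC4)cc3)nc2n(CC)c1=O` — > 1000 nM, a limit of the assay.
Compound 3 `CCCn1c(=O)c2[nH]c(-c3ccc(S(=O)(=O)N4CCN(c5ccc(Cl)cc5)CC4)cc3)nc2n(C)c1=O` — > 1000 nM, a limit of the assay.

In an assay on CHO cells for displacement of a labelled ligand from adenosine receptor A1 (Homo sapiens), read by scintillation counting, with a stated time of 90 min, in the presence of a further agent that is not named here (on this read-out lower numbers stand for stronger inhibition and higher numbers for weaker inhibition), compound 1 gives only a limit, > 1000 nM, and no number. Compound 2 likewise stands at a limit, > 1000 nM. Compound 3 also stands at a limit, > 1000 nM. Going by the values given here, the one single-point step among the measured compounds, a step that the two limits leave unreadable from compound 2 to compound 3, is therefore unreadable, since both of its ends are limits. All that the measured set shows is the limit of > 1000 nM in this assay, at which 3 of the 3 values shown sit.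

The new compound 4 `CCCn1c(=O)[nH]c2nc(-c3ccc(S(=O)(=O)N4CCN(c5ccc(I)cc5)CC4)cc3)[nH]c2c1=O` differs from compound 1 by 4-iodophenyl in place of 2-bromophenyl on an amine nitrogen in a ring. Among the compounds with values here, no measured step concerns a change of this kind, and the shared core of compound 1 has given no number in this assay in any of the three measured compounds. The step from compound 1 to compound 4 therefore cannot be read from a measured step, and the expectation rests on the observation that every compound of this set sits at the limit. On that basis compound 4 is expected to remain weak, most likely again as a limit, with an estimated step that the limit leaves unreadable from compound 1 to compound 4 of no readable size. The estimate for compound 4 is 3000 nM, in a range from 800 nM to 15000 nM.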

Compound 4, inhibition constant: > 1000 nM
Compound 4 was reported as a limit; the forecaster's own chance of this, stated with the estimate: 80%; the middle value is on the limit's open side.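

Compound 4 gives > 1000 nM in this assay and this is a limit of the assay, not a number. Going by these compounds alone, compound 1 also stands at a limit, so no step from compound 1 to compound 4 can be read. The compounds shown leave open how strongly any of them inhibits and whether 4-iodophenyl and 2-bromophenyl differ at all, because every value stops at the same limit: the limit of > 1000 nM in this assay, at which 4 of the 4 values shown sit.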